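A Dimethylamino Group Gives Way to an Imidazole

The compounds below may be only part of what the source reports. "The series", "measured", "known", "first", "only" and "open" are said of these compounds alone.

Three measured compounds share one core and differ only in the group on a saturated chain carbon bound to a saturated ring carbon. In a functional assay on HUVEC cells (Homo sapiens), read by scintillation counting and thymidine incorporation, with a stated time of 24 h (on this read-out lower numbers stand for stronger inhibition and higher numbers for weaker inhibition), compound 1 (`CCC(C)n1ncn(-c2ccc(N3CCN(c4ccc(OC[C@@H]5CO[C@@](CBr)(c6ccc(Cl)cc6Cl)O5)cc4)CC3)cc2)c1=O`) gives 569 nM with bromo at that place. Compound 2 (`CCC(C)n1ncn(-c2ccc(N3CCN(c4ccc(OC[C@@H]5CO[C@@](CN(C)C)(c6ccc(Cl)cc6Cl)O5)cc4)CC3)cc2)c1=O`) gives 1400 nM with dimethylamino, the highest of the three numbers and so the weakest inhibition here. Compound 3 (`CCC(C)n1ncn(-c2ccc(N3CCN(c4ccc(OC[C@@H]5CO[C@@](Cn6ccnc6C)(c6ccc(Cl)cc6Cl)O5)cc4)CC3)cc2)c1=O`) gives 173 nM with 2-methyl-1H-imidazol-1-yl. Compound 4 (`CCc1nccn1C[C@@]1(c2ccc(Cl)cc2Cl)OC[C@@H](COc2ccc(N3CCN(c4ccc(-n5cnn(C(C)CC)c5=O)cc4)CC3)cc2)O1`) is still unmeasured and carries 2-ethyl-1H-imidazol-1-yl in place of dimethylamino (2-ethyl-1H-imidazol-1-yl in place of dimethylamino on a saturated chain carbon bound to a saturated ring carbon). The nearest guide is the change to 2-methyl-1H-imidazol-1-yl (an 8.1-fold lower number from compound 2 to compound 3 (0.91 log units; beyond the scatter)), and the same group also gave a lower number than bromo (a 3.3-fold lower number from compound 1 to compound 3 (0.52 log units; beyond the scatter)). Bromo to dimethylamino went the other way (a 2.5-fold higher number from compound 1 to compound 2 (0.39 log units; beyond the scatter)). No measurement shows what ethyl in place of methyl does. In this assay a step of about the same size as the nearest guide, toward a lower number, is therefore expected (a 7.4-fold lower number from compound 2 to compound 4 (0.87 log units; beyond the scatter)). Compound 4 is estimated at 190 nM (expected range 70 nM to 500 nM).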

Compound 4, half-maximal inhibitory concentration: 224 nM
For compound 4 the middle estimate is 1.2-fold (0.07 log units) below the measured one, within the range that was stated.
By their numbers in this assay, from the lowest: compounds 3 and 4 (each within the scatter of the next); then compound 1; then compound 2.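

In this assay, the advantage over dimethylamino is not confined to the 2-methyl-1H-imidazol-1-yl group: 2-ethyl-1H-imidazol-1-yl also gives a clear step (a 6.3-fold lower number from compound 2 to compound 4 (0.80 log units; beyond the scatter)) and stands apart from bromo as well (a 2.5-fold lower number from compound 1 to compound 4 (0.40 log units; beyond the scatter)). Going from methyl to ethyl on the imidazole, which is methyl in place of hydrogen on a saturated chain carbon bound to an aromatic carbon, leaves the two compounds within the scatter of each other (a 1.3-fold higher number from compound 3 to compound 4 (0.11 log units; within the scatter)), so this change shows no measurable effect in either direction. No measured evidence here accounts for the difference between the imidazole groups and dimethylamino.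

Still open, on these data alone, is how an imidazole with hydrogen in place of the methyl or ethyl would read, or one carrying a longer chain such as propyl. Also open, as far as these compounds go, is whether another ring on that chain carbon, such as 1H-1,2,4-triazol-1-yl, would match these imidazoles.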